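The source may hold more compounds than are shown below. What is called first, only, known or untested is meant among the compounds shown, and "the series" means these compounds.

Measured values in a functional assay on HCT-116 cells (Homo sapiens) for inhibition, read by MTT assay, with a stated time of 48 h (on this read-out lower numbers stand for stronger inhibition and higher numbers for weaker inhibition), are as follows
- compound 1 `C/C=C/C(=O)N(Cc1ccc(OC)c(C)c1)c1cc(OC)c(OC)c(OC)c1` gives 23500 nM
- compound 2 `COc1ccc(CNc2cc(OC)c(OC)c(OC)c2)cc1C` gives 60900 nM
- compound 3 `C/C=C/C(=O)N(Cc1ccc(OC)c(Cl)c1)c1cc(OC)c(OC)c(OC)c1` has not yet been measured

Compound 1 at 23500 nM holds the lower of the two numbers in this assay and so stands as the better inhibitor of the pair. Compound 3 departs from it by chloro in place of methyl on an aromatic carbon as a swap of chloro in place of methyl on an aromatic carbon, ortho to a methoxy group and meta to a large group. Going by the values given here, the only measured step is a 2.6-fold higher number from compound 1 to compound 2 (0.41 log units; beyond the scatter) and it is modest. It replaces the (prop-1-en-1-yl)carbonyl on the nitrogen with hydrogen, at a different place in the molecule, so it bears only loosely on this swap. Among the compounds with values here, no measured compound varies the group that changes here, and the data give no direction for it. Since even the larger change in a 2.6-fold higher number from compound 1 to compound 2 (0.41 log units; beyond the scatter) moved the number only modestly, no step beyond the scatter is expected. The estimated step is a 1.2-fold lower number from compound 1 to compound 3 (0.07 log units; within the scatter) and it is a small one. Compound 3 is expected to give about 20000 nM in this assay as its estimate, within an expected range of 8000 nM to 50000 nM as the likely span.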

Compound 3, half-maximal inhibitory concentration: 1420 nM
The estimate for compound 3 lay 14-fold (1.15 log units) above the measured number; the measured number lies below the stated range.
By their numbers in this assay, from the lowest: compound 3; then compound 1; then compound 2.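

In this assay, chloro in place of methyl on an aromatic carbon, ortho to a methoxy group and meta to a large group, gives a 17-fold lower number from compound 1 to compound 3 (1.22 log units; beyond the scatter), which shows that this position on the aromatic ring responds strongly to the group it carries. The earlier pair varied only the group on the nitrogen, and its step, a 2.6-fold higher number from compound 1 to compound 2 (0.41 log units; beyond the scatter), is smaller, so the change from 4-methoxy-3-methylphenyl to 3-chloro-4-methoxyphenyl moves the number further than removing the (prop-1-en-1-yl)carbonyl did, even though the swap leaves the counts of heavy atoms, hydrogen-bond donors and hydrogen-bond acceptors as they were. Nothing available explains why this swap has so large an effect.

The compounds shown leave open how fluoro, bromo, trifluoromethyl or an amine would read at this same position, since a single pair gives the effect of chloro against methyl and no trend across groups. They also leave open whether chloro would bring a comparable step to compound 2, where hydrogen sits on the nitrogen in place of the (prop-1-en-1-yl)carbonyl.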